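Removing one methoxy group from compound 2

The source may report more compounds than this note shows. Statements on the series, on what has been measured and on what is new or still open speak of the compounds shown alone.

Measured so far:
compound 1, `COc1ccc(-c2cc(/C=C/C(=O)c3ccc(N)cc3)[nH]n2)cc1`, 101%
compound 2, `COc1cc(-c2cc(/C=C/C(=O)c3ccc(N)cc3)[nH]n2)cc(OC)c1OC`, 82%

Of the compounds shown here, two sharing one core have been measured. In a functional assay on SK-OV-3 cells (Homo sapiens) for cytotoxicity, read by sulforhodamine B assay, with a stated time of 48 h, tested at 0.01 uM (on this read-out lower numbers stand for a stronger effect and higher numbers for a weaker effect at the one concentration tested), compound 1 gives 101%, and in the same assay compound 2 gives 82%. Compound 2 thus holds the lowest of the two numbers, and its gap to compound 1 lies beyond the usual scatter. The next compound, compound 3, has the structure `COc1ccc(-c2cc(/C=C/C(=O)c3ccc(N)cc3)[nH]n2)cc1OC`. It differs from compound 2 in one place: hydrogen in place of methoxy on an aromatic carbon. Among the compounds with values here, no step between measured compounds that differ in only one place is at hand, so the size of this change is not known from the data. Compound 1, carrying fewer methoxy groups than compound 2, stands higher, and compound 3 lies between the two in its count of methoxy groups. Compound 3 is therefore expected to move back toward compound 1 by the step of a number 9 percentage points higher from compound 2 to compound 3 (within the scatter), a modest shift upward in the read-out. The value for compound 3 is estimated at 91%, with a range from 74% to 108%.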

Compound 3, a percentage reported as activity, at one concentration (the size of the read-out at that concentration, not a potency): 88%
The estimate for compound 3 lay 3 percentage points above the measured number, within the range that was stated.
By their numbers in this assay, from the lowest: compounds 2 and 3 (each within the scatter of the next); then compound 1.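

In this assay, hydrogen in place of methoxy on this aromatic carbon, ortho to a methoxy group and meta to a large group, gives a number 6 percentage points higher from compound 2 to compound 3 (within the scatter) and so shows that this methoxy group can leave without a change beyond the scatter. Within the data shown here, the step of methoxy in place of hydrogen on an aromatic carbon gives a number 13 percentage points lower from compound 1 to compound 3 (beyond the scatter) and is the first step of one place here to lie beyond the scatter, so the two methoxy changes differ in what they show. No measurement at hand bears on why these two steps come out as they do.

From the compounds shown here alone, whether a hydroxyl group, an amine or a longer alkoxy chain on this aromatic carbon would shift the number stays open. Also open, going by these compounds, is how these steps would look at any concentration other than the one used in this assay.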